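The source may hold more compounds than are shown below. What is called first, only, known or untested is meant among the compounds shown, and "the series" means these compounds.

Measured so far in a physicochemical assay for lipophilicity, read by HPLC; a lower number here means a more polar compound, a higher number a more lipophilic compound:

Compound 1 `Cc1ccsc1C(=CCCN(C)C(CCN)C(=O)NCc1ccccc1Cl)c1sccc1C` gives 6.11
Compound 2 `Cc1ccsc1C(=CCCN(C)C(CCN)C(=O)NCc1ccccc1)c1sccc1C` gives 5.5

Compound 2 has the lower number of the two, beyond the scatter from compound 1. Compound 3 `Cc1ccsc1C(=CCCN(C)C(CCN)C(=O)NCc1ccc(F)cc1)c1sccc1C` differs from compound 2 by fluoro in place of hydrogen on an aromatic carbon and carries fluoro in place of hydrogen on an aromatic carbon, para to a large group. Among the compounds with values here, one measured step bears on this change: a number 0.61 log units lower from compound 1 to compound 2 (beyond the scatter) with hydrogen in place of chloro on an aromatic carbon. Fluoro is not chloro, and a single step is only a loose guide. A smaller step in the opposite direction is expected, a number 0.20 log units higher from compound 2 to compound 3 (within the scatter) in this assay and perhaps no larger than the scatter. Compound 3 is estimated at 5.7 with an expected range from 5.4 to 6.05 for this measurement.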

Compound 3, partition coefficient: 6.45
Beside the measured number, compound 3's estimate is 0.75 log units below it, and the stated range ends below it.
By their numbers in this assay, from the lowest: compound 2; then compound 1; then compound 3.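

In this assay, putting fluoro in place of hydrogen on the aromatic carbon para to a large group gives a number 0.95 log units higher from compound 2 to compound 3 (beyond the scatter), a rise rather than a change lost in the scatter. Exchanging the 2-chlorophenyl for the 4-fluorophenyl gives a number 0.34 log units higher from compound 1 to compound 3 (beyond the scatter), which places compound 3 highest of the three. No measurement here accounts for this rise.

Compound 1 and compound 3 differ in both the halogen and its place, so the two influences remain unseparated. Going by these compounds, how a bromo or methyl group would read at this same place remains open.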